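The source may report more compounds than this note shows. Statements on the series, on what has been measured and on what is new or still open speak of the compounds shown alone.

Measured so far in an ADME assay on S9 fraction from liver (Rattus norvegicus) for metabolic stability, read by LC-MS, using NADPH, with a stated time of 30 min; a lower number here means that less of the compound is left, a higher number that more of the compound is left:

- compound 1 `CCCCCCCCc1ccc(OCC(=O)Cn2nnc(-c3ccccc3)n2)cc1`: 33%
- compound 2 `CCCCCCCCc1ccc(OCC(=O)Cn2nnc(-c3cccc(C(=O)OC)c3)n2)cc1`: 19%
- compound 3 `CCCCCCCCc1ccc(OCC(=O)Cn2nnc(-c3ccc(S(=O)(=O)N(C)C)cc3)n2)cc1`: 65%

Compound 2 stands lowest of the three numbers, beyond the scatter against both others: a number 14 percentage points lower from compound 1 to compound 2 (beyond the scatter), and a number 46 percentage points higher from compound 2 to compound 3 (beyond the scatter).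

Compound 4 `CCCCCCCCc1ccc(OCC(=O)Cn2nnc(CCC(=O)O)n2)cc1` follows from compound 2 by 2-carboxyethyl in place of 3-(methoxycarbonyl)phenyl on an aromatic carbon.

Every step measured so far changes the group on this same ring atom, and every one of them moved the number beyond the scatter: a number 14 percentage points lower from compound 1 to compound 2 (beyond the scatter), a number 32 percentage points higher from compound 1 to compound 3 (beyond the scatter), a number 46 percentage points higher from compound 2 to compound 3 (beyond the scatter). None of them removes the six-membered aromatic ring altogether, as the step to compound 4 does, so the direction rests on a thin base. What the three compounds show is that compound 2 sits at the bottom and that both other groups at this place gave higher numbers, the larger change the larger rise. A step beyond the scatter is therefore expected for compound 4, more likely upward than downward, but of uncertain size.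

Compound 4 is expected to give 40%, within 20% to 65%, that is an estimated a number 21 percentage points higher from compound 2 to compound 4 (beyond the scatter).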

Compound 4, percent of the compound remaining: < 5%
Compound 4: no number, only a limit (the forecaster's own chance of this, stated with the estimate: 3%); middle value at least 35 percentage points from the limit.
By their numbers in this assay, from the lowest: compound 2; then compound 1; then compound 3. At a limit, below all of these: compound 4.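

In this assay compound 4 gives < 5%, which is a limit of the assay and not a number: the limit of < 5% in this assay, at which 1 of the 4 values shown sits.

Set against the three compounds that carry a six-membered aromatic ring at this place, 2-carboxyethyl falls on the low side of each: a number at least 14 percentage points lower from compound 2 to compound 4 (beyond the scatter), a number at least 28 percentage points lower from compound 1 to compound 4 (beyond the scatter), and a number at least 60 percentage points lower from compound 3 to compound 4 (beyond the scatter). Compound 2 is therefore no longer the bottom of the series, and the rise seen with the dimethylsulfamoyl group in compound 3 does not carry over to this first group without a ring on the aromatic carbon of the five-membered aromatic ring with 4 nitrogen.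

The change to compound 4 takes away the six-membered aromatic ring and brings in a carboxylic acid in a single step, so the compounds shown cannot tell which of the two goes with the low value. The methyl ester of the 2-carboxyethyl chain, a plain alkyl chain of similar length, or a phenyl ring carrying a carboxylic acid would separate the two, and the limit leaves the full size of all three steps open.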